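Moving two fluorines: from compound 3 to compound 4

This account rests on a few compounds, and the source may have more. Where it says the series, first, only, none or still open, it means among the compounds named here.

In a functional assay on A-375 cells (Homo sapiens) for activation, with a stated time of 3 days (a lower number here means that less compound is needed, a higher number that more compound is needed for the effect), compound 1 (`O=C(Nc1ccc(-c2cscn2)cc1)C1CCCN(Cc2ccccc2F)C1`) gives 7000 nM, compound 2 (`O=C(Nc1ccc(-c2cscn2)cc1)C1CCCN(Cc2cccc(F)c2)C1`) gives 5000 nM and compound 3 (`O=C(Nc1ccc(-c2cscn2)cc1)C1CCCN(Cc2cc(F)cc(F)c2)C1`) gives 1500 nM, the lowest of the three numbers. Compound 4 (`O=C(Nc1ccc(-c2cscn2)cc1)C1CCCN(Cc2cccc(F)c2F)C1`) is unmeasured and carries 2,3-difluorophenyl in place of 3,5-difluorophenyl on a saturated chain carbon bound to an amine nitrogen in a ring. Among the measured compounds shown here, three measured steps bear on this change. The step of a 1.4-fold lower number from compound 1 to compound 2 (0.15 log units; within the scatter) stays within the scatter, while a 3.3-fold lower number from compound 2 to compound 3 (0.52 log units; beyond the scatter) and a 4.7-fold lower number from compound 1 to compound 3 (0.67 log units; beyond the scatter) are modest drops, both ending at 3,5-difluorophenyl. The entering group combines the fluorines of the 2-fluorophenyl and 3-fluorophenyl groups, so a modest rise is expected in this assay, a 2.3-fold higher number from compound 3 to compound 4 (0.37 log units; beyond the scatter). The estimate for compound 4 is 3500 nM, with an expected range of 1300 nM to 9000 nM.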

Compound 4, half-maximal effective concentration: 10000 nM
Compound 4: middle estimate off by 2.9-fold (0.46 log units), on the low side, and the stated range ends below it.
By their numbers in this assay, from the lowest: compound 3; then compounds 2, 1 and 4 (each within the scatter of the next).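

In this assay, the placing of the two fluorines matters, not just their number (a 6.7-fold higher number from compound 3 to compound 4 (0.82 log units; beyond the scatter)). The 2,3-difluorophenyl group brings no clear change from either group with a single fluorine (a 2.0-fold higher number from compound 2 to compound 4 (0.30 log units; within the scatter); a 1.4-fold higher number from compound 1 to compound 4 (0.15 log units; within the scatter)). Fluoro in place of hydrogen on an aromatic carbon therefore does not carry over from one compound to another: (the same change on two cores in this assay, a 3.3-fold lower number (0.52 log units; beyond the scatter) from compound 2 to compound 3 and a 1.4-fold higher number (0.15 log units; within the scatter) from compound 1 to compound 4, 4.8-fold (0.68 log units) apart, beyond the scatter of two such steps).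

As far as these compounds go, it stays open whether chloro or methoxy groups in place of the two fluorines of 3,5-difluorophenyl would keep the low number of compound 3. These compounds also cannot tell why the placing matters.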